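This account rests on a few compounds, and the source may have more. Where it says the series, first, only, none or still open, it means among the compounds named here.

Three long-chain compounds frame this account, all tested in a functional assay on K562 cells (Homo sapiens) for cytotoxicity, read by MTT assay; a lower number here means that less compound is tolerated, a higher number that more compound is tolerated. Compound 1 `C/C(=C/CC[C@@H](C)CC(=O)O)CC/C=C(/C)CCCc1ccoc1` gives > 100 ug/mL, which is a limit of the assay and not a number. Compound 2 `COC(=O)C(C)(O)[C@](O)(C[C@H](C)CCC/C(C)=C/CC/C(C)=C/CCc1ccoc1)C(=O)OC` gives 20 ug/mL, and compound 3 `COC1C=C(CC/C=C(\C)CC/C=C(\C)CCC[C@@H](C)/C=C2\OC(=O)C(C)=C2O)C(OC)O1` gives 80 ug/mL. Compound 3 therefore holds the higher of the two true numbers, and its gap to compound 2 lies beyond the scatter.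

Compound 4 `CC1=C(O)/C(=C/[C@H](C)CCC/C(C)=C/CC/C(C)=C/CCC2=CC(O)OC2=O)OC1=O` has not yet been measured. Its difference from compound 3 is a group of 7 heavy atoms (4 carbon, 3 oxygen; one five-membered non-aromatic ring with 1 hetero atom) in place of a group of 9 heavy atoms (6 carbon, 3 oxygen; one five-membered non-aromatic ring with 1 hetero atom), on a saturated chain carbon, two bonds along the chain from a double-bonded chain carbon. The exchanged group is a five-membered non-aromatic ring with 1 hetero atom on both sides, and the change falls on a saturated chain carbon, two bonds along the chain from a double-bonded chain carbon.

Within the data shown here, no measured pair of compounds differs in one place alone, so the data do not show directly what this exchange does in this assay. Among the measured compounds shown here, the only guide is the spread of the numbers, from compound 2 at 20 ug/mL to compound 3 at 80 ug/mL, and a value inside that spread seems most likely. The expected change is a moderate fall, estimated as a 2.3-fold lower number from compound 3 to compound 4 (0.36 log units; beyond the scatter). This is uncertain, and a result close to compound 3 would not be surprising. For compound 4 the estimated value is 35 ug/mL, with an expected range of 10 ug/mL to 100 ug/mL.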

Compound 4, concentration lethal to 50% of the cells: > 100 ug/mL
Compound 4 was reported as a limit; the forecaster's own chance of this, stated with the estimate: 15%; at least 2.8-fold (0.45 log units) between middle value and limit.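

In this assay compound 4 gives > 100 ug/mL, which is a limit of the assay and not a number. Among these compounds, this is the first step between measured compounds that differ in one place, and it shows no fall when the group of 7 heavy atoms replaces the group of 9 heavy atoms on a saturated chain carbon, two bonds along the chain from a double-bonded chain carbon: the exchange gives an at least 1.2-fold higher number from compound 3 to compound 4 (0.09 log units; that floor lies within the scatter), and only that floor, not the true size of the step, can be read. The step may be larger than its floor, yet its size stays unknown because the value of compound 4 rests at the assay's limit: the limit of > 100 ug/mL in this assay, at which 2 of the 4 values shown sit.

The compounds shown leave open whether the hydrogen-bond donor or the additional double bond of the entering group, or the smaller size of that group, accounts for the change, since all of these differ together in this one exchange. They also leave open what an amine or an amide at the same place would do in this assay.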